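A few compounds are considered here, and "the series" means these few. Any claim that something is new, unique, unknown or untested is made for them only; others in the source may bear on it.

Compound 3 `O=S(=O)(Nc1ccccn1)c1ccc(N/C(S)=N\c2ccnc3cc(C(F)(F)F)ccc23)cc1` belongs to a small set of three measured compounds that share one core. In a functional assay on HeLa cells (Homo sapiens) for antiproliferative activity, read by sulforhodamine B assay, with a stated time of 48 h (on this read-out lower numbers stand for stronger inhibition and higher numbers for weaker inhibition), compound 3 gives 68800 nM, which places it second highest of the three numbers; compound 2 `O=S(=O)(Nc1nccs1)c1ccc(N/C(S)=N\c2ccnc3cc(C(F)(F)F)ccc23)cc1` gives 95200 nM and compound 1 `O=C(Nc1ccccc1)Nc1ccc(S(=O)(=O)Nc2ccnc3cc(C(F)(F)F)ccc23)cc1` gives 41000 nM, and both of those numbers lie within the scatter of compound 3. Compound 4 `COc1ncnc(NS(=O)(=O)c2ccc(N/C(S)=N\c3ccnc4cc(C(F)(F)F)ccc34)cc2)c1OC` is not yet measured. It differs from compound 3 only in the group on the sulfonamide nitrogen: 5,6-dimethoxypyrimidin-4-yl in place of pyridin-2-yl on a sulfonamide nitrogen. Among the measured compounds shown here, one measured step bears on this change, since it also exchanges the group on that same nitrogen: a 1.4-fold lower number from compound 2 to compound 3 (0.14 log units; within the scatter). That exchange left the number essentially where it was. The exchange from compound 3 to compound 4 is a different one, and a single step is a thin basis, so the expectation in this assay is a step of no more than the scatter, in no preferred direction, namely a 1.1-fold lower number from compound 3 to compound 4 (0.06 log units; within the scatter). Compound 4 is therefore estimated at 60000 nM, with a range from 25000 nM to 150000 nM.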

Compound 4, half-maximal inhibitory concentration: "not active" (no number reported)
The entry for compound 4 holds no number; there is nothing to compare the estimate with.
By their numbers in this assay, from the lowest: compounds 1, 3 and 2 (each within the scatter of the next, the first and the last beyond it).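

In this assay, among the compounds shown here, compound 4 is reported as "not active" with no number, so no step from compound 3 to compound 4 can be read. As far as these compounds go, whether 5,6-dimethoxypyrimidin-4-yl in place of pyridin-2-yl shifts the number, and how far, stays open. No available evidence bears on this result.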